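Trading a nitro for a chlorine on the anilino ring

The source may hold more compounds than are shown below. What is called first, only, known or untested is meant among the compounds shown, and "the series" means these compounds.

Of the compounds shown here, three sharing one core have been tested in a functional assay on NCI-H1975 cells (Homo sapiens) for inhibition, read by MTT assay, with a stated time of 72 h; a higher number here means a weaker inhibitor, a lower number a stronger inhibitor. Compound 1 `C=CC(=O)Nc1cccc(NC(=O)CSc2nc(Nc3ccccc3)c3ccccc3n2)c1` gives 8120 nM, compound 2 `C=CC(=O)Nc1cccc(NC(=O)CSc2nc(Nc3ccccc3C)c3ccccc3n2)c1` gives 9920 nM, and compound 3 `C=CC(=O)Nc1cccc(NC(=O)CSc2nc(Nc3cccc([N+](=O)[O-])c3)c3ccccc3n2)c1` gives 22600 nM, the highest of the three numbers and therefore the weakest inhibitor so far. The two changes that lead to compound 3 both raise the number: a 2.8-fold higher number from compound 1 to compound 3 (0.44 log units; beyond the scatter) and a 2.3-fold higher number from compound 2 to compound 3 (0.36 log units; beyond the scatter), while a 1.2-fold higher number from compound 1 to compound 2 (0.09 log units; within the scatter).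

Compound 4 `C=CC(=O)Nc1cccc(NC(=O)CSc2nc(Nc3ccc(Cl)cc3)c3ccccc3n2)c1` has not yet been measured. It differs from compound 3 in one place: 4-chlorophenyl in place of 3-nitrophenyl on a nitrogen on an aromatic ring. Taking away the nitro group reverses the change that raised the number from compound 1 to compound 3, so a return toward the numbers of compound 1 and compound 2 seems the natural expectation. Among the measured compounds shown here, nothing among the measured compounds speaks to what a chlorine on the phenyl ring does, so that part of the change is left open.

Compound 4 is therefore expected to land close to compound 1 and compound 2 in this assay, with an estimated step of a 2.5-fold lower number from compound 3 to compound 4 (0.40 log units; beyond the scatter). The estimate for compound 4 is 9000 nM, with a range from 4500 nM to 18000 nM.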

Compound 4, half-maximal inhibitory concentration: 7580 nM
Compound 4: middle estimate off by 1.2-fold (0.07 log units), on the high side, within the range that was stated.
By their numbers in this assay, from the lowest: compounds 4, 1 and 2 (each within the scatter of the next); then compound 3.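

In this assay, 4-chlorophenyl in place of 3-nitrophenyl on the nitrogen gives a 3.0-fold lower number from compound 3 to compound 4 (0.47 log units; beyond the scatter), so the higher number of compound 3 does not carry over to this replacement. The chlorine itself makes no readable difference, with a 1.1-fold lower number from compound 1 to compound 4 (0.03 log units; within the scatter) and a 1.3-fold lower number from compound 2 to compound 4 (0.12 log units; within the scatter), both within the scatter; compounds 1, 2 and 4 therefore cannot be told apart, and among the four compounds only compound 3, with its nitro group, stands apart from them. Nothing measured here accounts for compound 3 standing apart from the other three.

The change from compound 3 to compound 4 alters both the group on the ring and where it sits, so these compounds cannot separate the effect of swapping nitro for chlorine from the effect of moving the group. As far as these compounds go, how a methoxy group, an amine or a carboxylic acid on this ring would read also remains open, which leaves unsettled whether nitro is a lone exception among groups at this position.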